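A Hydroxy Added to a Compound at the Assay Limit

This account rests on a few compounds, and the source may have more. Where it says the series, first, only, none or still open, it means among the compounds named here.

In a functional assay on H184B5F5/M10 cells (Homo sapiens) for antiproliferative activity, read by MTT assay, with a stated time of 24 h (a higher number here means a weaker inhibitor, a lower number a stronger inhibitor), compound 1 `COc1cc(/C=C/C(=O)NNC(=O)c2ccccc2)ccc1O` gives 9170 nM. Compound 2 `COc1cc(/C=C/C(=O)NNC(=O)c2ccccc2)cc(OC)c1O` is reported only as a limit, > 10000 nM. Compound 3 `COc1cc(/C=C/C(=O)NNC(=O)c2ccc(O)cc2)cc(OC)c1O` differs from compound 2 by hydroxy in place of hydrogen on an aromatic carbon, which is hydroxy in place of hydrogen on an aromatic carbon, or phenyl to 4-hydroxyphenyl. Within the data shown here, the only measured step is an at least 1.0-fold higher number from compound 1 to compound 2 (0.03 log units; that floor lies within the scatter), for methoxy in place of hydrogen on an aromatic carbon. Among the measured compounds shown here, with only that different change as a guide, no shift in either direction beyond the scatter is expected. The expected change is a number no higher from compound 2 to compound 3 (the limit leaves the size open). Compound 3 is estimated at 10000 nM, within an expected range of 4000 nM to 25000 nM.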

Compound 3, half-maximal inhibitory concentration: > 10000 nM
Compound 3 was reported as a limit; the forecaster's own chance of this, stated with the estimate: 55%; the middle value sits exactly at the limit.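

Compound 2 and compound 3 both stand only as limits in this assay, so no step between them can be read: the limit of > 10000 nM in this assay, at which 2 of the 3 values shown sit.

As far as these compounds go, whether hydroxy in place of hydrogen on an aromatic carbon shifts the number at all, and in which direction, stays open.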